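Replacing 3,4,5-trimethoxyphenyl with 2-chloropyridin-3-yl on compound 2

The source may hold more compounds than are shown below. What is called first, only, known or untested is meant among the compounds shown, and "the series" means these compounds.

In a functional assay on A549 cells (Homo sapiens) for inhibition, read by sulforhodamine B assay, with a stated time of 48 h, tested at 50 uM (on this read-out lower numbers stand for less inhibition of growth and higher numbers for more inhibition of growth at the one concentration tested), compound 1 `COc1cc2c(cc1CCC(C)C)C(=O)C[C@@H](c1ccc(O)cc1)O2` gives 75%. Within the data shown here, compound 2 `COc1ccc([C@@H]2C/C(=N/OCc3cn(-c4cc(OC)c(OC)c(OC)c4)nn3)c3cc(CC=C(C)C)c(OC)cc3O2)cc1` gives 28% in this assay, the lower of the two numbers so far, and its gap to compound 1 lies beyond the scatter. These two compounds differ in more than one place, so their gap cannot be assigned to any single group.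

Compound 3 `COc1ccc([C@@H]2C/C(=N/OCc3cn(-c4cccnc4Cl)nn3)c3cc(CC=C(C)C)c(OC)cc3O2)cc1` keeps the rest of compound 2 and changes one group: 2-chloropyridin-3-yl in place of 3,4,5-trimethoxyphenyl on an aromatic nitrogen. Here, 2-chloropyridin-3-yl stands in place of 3,4,5-trimethoxyphenyl on an aromatic nitrogen of a five-membered aromatic ring with 3 nitrogen. Among the measured compounds shown here, no measured pair isolates this change, so the data offer no direct guide to its size or direction.

The low position of compound 2 at 28% leaves more room for a rise than for a fall. The change expected is therefore small and upward, an estimated a number 7 percentage points higher from compound 2 to compound 3 (within the scatter), which stays within the scatter. For compound 3 the expected value is 35%, with an estimated range from 15% to 58%.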

Compound 3, percent growth inhibition at one concentration: 58%
Beside the measured number, compound 3's estimate is 23 percentage points below it; measured number inside the range.
By their numbers in this assay, from the lowest: compound 2; then compound 3; then compound 1.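

The group on the aromatic nitrogen of the five-membered aromatic ring with 3 nitrogen proves able to move growth inhibition on its own: in this assay, putting 2-chloropyridin-3-yl in place of 3,4,5-trimethoxyphenyl gives a number 30 percentage points higher from compound 2 to compound 3 (beyond the scatter), the only step shown that can be tied to a single group. The gain comes with a change to a group with fewer heavy atoms and fewer hydrogen-bond acceptors, which shows that the larger 3,4,5-trimethoxyphenyl is not needed at this place for growth inhibition in this assay. The entering group also brings a chlorine and a ring nitrogen, and nothing measured here explains the rise or ties it to any one of these differences.

Going by these compounds, a plain pyridin-3-yl or a 2-chlorophenyl on the same aromatic nitrogen would separate the part played by the chlorine from that of the ring nitrogen, and that question remains open. Also open, on these data alone, is whether the step keeps its size when other parts of the shared core change, since it rests on this one pair of compounds.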